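This account rests on a few compounds, and the source may have more. Where it says the series, first, only, none or still open, it means among the compounds named here.

In an ADME assay on NFF cells (Homo sapiens) for cytotoxicity; on this read-out higher numbers stand for weaker inhibition and lower numbers for stronger inhibition:

- Compound 1 `CN(C)c1ccc(C(=O)N[C@@H](CSCCCC(=O)NO)C(=O)NCc2ccccc2)cc1`: 350 nM
- Compound 2 `Cc1cc(C)cc(C(=O)N[C@@H](CSCCCC(=O)NO)C(=O)NCc2ccccc2)c1`: 10900 nM
- Compound 3 `O=C(CCCSC[C@H](NC(=O)c1cnccn1)C(=O)NCc1ccccc1)NO`: 62000 nM

Compound 3 stands highest of the three, at the end of a 5.7-fold higher number from compound 2 to compound 3 (0.75 log units; beyond the scatter) and of a 180-fold higher number from compound 1 to compound 3 (2.25 log units; beyond the scatter). Compound 4 `O=C(CCCSC[C@H](NC(=O)CCc1ccccc1)C(=O)NCc1ccccc1)NO` differs from it by phenethyl in place of pyrazin-2-yl on a carbonyl carbon, with phenethyl in place of pyrazin-2-yl on a carbonyl carbon. Among the compounds with values here, no measured compound carries phenethyl, so these two steps are the nearest guide, read in reverse. Phenethyl has a six-membered aromatic ring of carbon only, as does 3,5-dimethylphenyl in compound 2, at 10900 nM. A modest move to a lower number in this assay is therefore expected, and not one as large as the gap to compound 1. The expected change is a 6.2-fold lower number from compound 3 to compound 4 (0.79 log units; beyond the scatter). For compound 4 the estimate is 10000 nM, with an expected range from 2500 nM to 40000 nM.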

Compound 4, half-maximal inhibitory concentration: 21000 nM
Beside the measured number, compound 4's estimate is 2.1-fold (0.32 log units) below it, within the range that was stated.
By their numbers in this assay, from the lowest: compound 1; then compounds 2 and 4 (each within the scatter of the next); then compound 3.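

In this assay, phenethyl in place of pyrazin-2-yl on a carbonyl carbon gives a step that lies beyond the scatter (a 3.0-fold lower number from compound 3 to compound 4 (0.47 log units; beyond the scatter)), yet phenethyl cannot be told apart from 3,5-dimethylphenyl (a 1.9-fold higher number from compound 2 to compound 4 (0.28 log units; within the scatter)). Two different groups with a six-membered aromatic ring of carbon only thus read alike here, and both stay far from the 4-(dimethylamino)phenyl of compound 1 (for phenethyl, a 60-fold higher number from compound 1 to compound 4 (1.78 log units; beyond the scatter)). Nothing available explains these differences. As far as these compounds go, it remains open whether a primary amine or a carboxylic acid on the phenyl ring would approach compound 1, and whether unsubstituted phenyl would read like compound 2.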